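Chloro in place of hydrogen on compound 3

The source may report more compounds than this note shows. Statements on the series, on what has been measured and on what is new or still open speak of the compounds shown alone.

In a functional assay on the whole organism for antagonist activity, with Mus musculus as the target (a lower number here means that less compound is needed, a higher number that more compound is needed for the effect), compound 3 (`NCC(=O)NCC(=O)Nc1ccc([N+](=O)[O-])cc1C(=O)c1ccccc1`) gives 4.82 mg/kg, within the scatter of compound 2 (`CN(C(=O)CNC(=O)CN1CCCCC1)c1ccc(Cl)cc1C(=O)c1ccccc1Cl`) at 7.5 mg/kg and clearly lower than compound 1 (`CC(=O)NCC(=O)Nc1ccc(Cl)cc1C(=O)c1ccccc1`) at 37 mg/kg. Compound 4 (`NCC(=O)NCC(=O)Nc1ccc([N+](=O)[O-])cc1C(=O)c1ccccc1Cl`) takes chloro in place of hydrogen on an aromatic carbon, ortho to a large group, so that phenyl becomes 2-chlorophenyl: chloro in place of hydrogen on an aromatic carbon. Going by the values given here, no measured pair isolates this change. Compound 2 also carries 2-chlorophenyl and gives 7.5 mg/kg, but it differs from compound 3 elsewhere, so it offers only indirect support. A modest fall in the number is expected, with an estimated 1.9-fold lower number from compound 3 to compound 4 (0.29 log units; within the scatter). For compound 4 the estimated value is 2.5 mg/kg, with an expected range of 1 mg/kg to 6 mg/kg.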

Compound 4, dose for half-maximal effect: 2.64 mg/kg
Compound 4: middle estimate off by 1.1-fold (0.02 log units), on the low side, and the stated range covers the measured number.
By their numbers in this assay, from the lowest: compounds 4, 3 and 2 (each within the scatter of the next, the first and the last beyond it); then compound 1.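

In this assay, going by these compounds alone, this pair isolates chloro in place of hydrogen on an aromatic carbon for the first time, turning phenyl into 2-chlorophenyl with everything else held constant (a 1.8-fold lower number from compound 3 to compound 4 (0.26 log units; within the scatter)). The step lies within the scatter, so this position accepts chloro without a clear change in the number. No measurement available here bears on the reason for this result.

As far as these compounds go, whether fluoro, methyl or methoxy on the same aromatic carbon would give a step beyond the scatter remains open. Also open, from the compounds shown here alone, is whether the same step holds when the other parts of the molecule differ.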